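Replacing the aminocyclohexyl group on compound 1 with an ester chain

The compounds below may be only part of what the source reports. "The series", "measured", "known", "first", "only" and "open" are said of these compounds alone.

Among the compounds with values here, compound 1 `N[C@H]1CC[C@H](Nc2c(C(=O)NCc3ccc(F)cc3)nc(Br)c3cccnc23)CC1` gives 6000 nM in a functional assay on MDA-MB-435 cells (Homo sapiens) for cytotoxicity, read by MTT assay, with a stated time of 72 h (a lower number here means a stronger inhibitor, a higher number a weaker inhibitor), the highest of the two numbers measured so far; compound 2 `N[C@H]1CC[C@H](Nc2c(C(=O)NCc3ccc(Cl)cc3Cl)nc(Br)c3cccnc23)CC1` gives 5800 nM, and the step of a 1.0-fold lower number from compound 1 to compound 2 (0.01 log units; within the scatter) is within the scatter. Compound 3 `COC(=O)CNc1c(C(=O)NCc2ccc(F)cc2)nc(Br)c2cccnc12` differs from compound 1 in one place: (methoxycarbonyl)methyl in place of 4-aminocyclohexyl on a nitrogen on an aromatic ring. Within the data shown here, no measured step touches this position, so nothing measured bears directly on the change. Compound 3 is therefore expected to give 6000 nM, between 1500 nM and 24000 nM, with no step beyond the scatter expected in no change at the digits printed from compound 1 to compound 3 (within the scatter).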

Compound 3, half-maximal inhibitory concentration: 10000 nM
Compound 3: the middle estimate sits 1.7-fold (0.22 log units) below what was measured, and the stated range covers the measured number.
By their numbers in this assay, from the lowest: compounds 2, 1 and 3 (each within the scatter of the next).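

In this assay, within the data shown here, the exchange of 4-aminocyclohexyl for (methoxycarbonyl)methyl on a nitrogen on an aromatic ring gives a 1.7-fold higher number from compound 1 to compound 3 (0.22 log units; within the scatter) and is the first measured change at this position. The ring, the amine and the defined stereocentres of 4-aminocyclohexyl can therefore all be lost without a step beyond the scatter. Nothing at hand explains this result.

Going by these compounds, whether a carboxylic acid in place of the methyl ester, or a longer chain ending in an amine, would also stay within the scatter remains open. So does whether the ester chain would give the same result alongside the 2,4-dichlorophenyl group of compound 2.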